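Swap of the 4-fluorophenoxy group in compound 2

The compounds below may be only part of what the source reports. "The series", "measured", "known", "first", "only" and "open" are said of these compounds alone.

Measured so far:
compound 1 `O=C(O)CC/C=C\CC1COC(c2cccnc2)OC1c1cccnc1` — 220 nM
compound 2 `CC(C)(Oc1ccc(F)cc1)C1OCC(C/C=C\CCC(=O)O)C(c2cccnc2)O1` — 51 nM

In an assay for inhibition of Thromboxane-A synthase (Homo sapiens), using microsomes (a higher number here means a weaker inhibitor, a lower number a stronger inhibitor), compound 2 has the lowest number of the two; compound 1 sits at a gap beyond the scatter. Compound 3 `Cc1ccc(SC(C)(C)C2OCC(C/C=C\CCC(=O)O)C(c3cccnc3)O2)c([N+](=O)[O-])c1` is not yet measured. Its change from compound 2: a group of 11 heavy atoms (7 carbon, 1 nitrogen, 2 oxygen, 1 sulfur; one six-membered aromatic ring of carbon only) in place of a group of 8 heavy atoms (6 carbon, 1 oxygen, 1 fluorine; one six-membered aromatic ring of carbon only), on a saturated chain carbon bound to two saturated chain carbons and a saturated ring carbon. Within the data shown here, no measured step of this kind is available, so the direction is open. The step of a 1.2-fold higher number from compound 2 to compound 3 (0.07 log units; within the scatter) is expected to stay within the scatter, with a wide band allowed either way. Compound 3 is estimated at 60 nM, in the range 20 nM to 200 nM.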

Compound 3, half-maximal inhibitory concentration: 30 nM
The estimate for compound 3 lay 2.0-fold (0.30 log units) above the measured number; the range from low to high includes it.
By their numbers in this assay, from the lowest: compounds 3 and 2 (each within the scatter of the next); then compound 1.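

At the saturated chain carbon bound to two saturated chain carbons and a saturated ring carbon, this assay accepts a very different aryl group: replacing 4-fluorophenoxy with the group of 11 heavy atoms gives a 1.7-fold lower number from compound 2 to compound 3 (0.23 log units; within the scatter) and does not separate the two compounds. The added sulfur, nitro group and methyl group therefore leave the read-out within the scatter. No measurement at hand gives a reason for this. On these data alone, it remains open whether an amine or a plain alkyl chain at this place would hold the number in the same range.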